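Ether side chain swaps on a shared core

The source may report more compounds than this note shows. Statements on the series, on what has been measured and on what is new or still open speak of the compounds shown alone.

Compound 2 `CC(C)=CCOc1cccc2ccc(N)nc12` carries a 2-methylprop-1-en-1-yl group on a saturated chain carbon bound to an oxygen on an aromatic ring. In an assay on cells with melanin-concentrating hormone receptor 1 (Homo sapiens) as the target, read by radioligand binding (a lower number here means a stronger inhibitor, a higher number a weaker inhibitor), compound 2 returns only a limit, > 2000 nM. Its measured neighbour, compound 1 `CC#CCCOc1cccc2ccc(N)nc12`, has but-2-yn-1-yl at that position instead. In this assay compound 1 likewise gives only a limit, > 2000 nM. The step that the two limits leave unreadable from compound 1 to compound 2 can therefore not be read; the limit of > 2000 nM in this assay, at which 2 of the 2 values shown sit, is all the two values show.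

Compound 3 `CSCCOc1cccc2ccc(N)nc12` is the next variation: (methylsulfanyl)methyl in place of 2-methylprop-1-en-1-yl on a saturated chain carbon bound to an oxygen on an aromatic ring. Among the compounds with values here, the single measured step that bears on this change is the unreadable one just named, so it yields neither a size nor a direction for this assay. What remains is that both measured chain variants sit at the limit, and the new chain variant is expected to stay weak as well. The expected step is a step that the limit leaves unreadable from compound 2 to compound 3, that is none beyond the scatter. Compound 3 is accordingly estimated at 3000 nM in this assay, with a range from 800 nM to 15000 nM, and most probably again only a limit.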

Compound 3, half-maximal inhibitory concentration: > 2000 nM
Compound 3: only a limit was reported; the forecaster's own chance of this, stated with the estimate: 70%; the middle value is on the limit's open side.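

No step among compound 1, compound 2 and compound 3 can be read in this assay, and all that the three values show is a single shared limit: the limit of > 2000 nM in this assay, at which 3 of the 3 values shown sit.

The compounds shown leave open how far each of these ether chains lies from that limit, and whether any chain on the shared core gives a measurable value.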